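Acetyl in place of propyl: from compound 3 to compound 4

The source may report more compounds than this note shows. Statements on the series, on what has been measured and on what is new or still open speak of the compounds shown alone.

Measured compounds, all tested in an assay on isolated protein for inhibition of serine/threonine-protein kinase TNNI3K (Homo sapiens); a lower number here means a stronger inhibitor, a higher number a weaker inhibitor:
compound 1, `CNc1cc(Oc2c(F)cc(NC(=O)Nc3cccc(C(F)(F)F)c3)cc2F)ncn1`, gives 20 nM.
compound 2, `CNc1cc(Oc2ccc(NC(=O)Nc3cccc(C(F)(F)F)c3)cc2Cl)ncn1`, gives 50 nM.
compound 3, `CCCNc1cc(Oc2ccc(NC(=O)Nc3cccc(C(F)(F)F)c3)cc2)ncn1`, gives 32 nM.

Compound 3 holds the second highest of the three numbers in this assay. Its nearest neighbour is compound 2, whose number is higher, and the furthest is compound 1, whose number is lower; both gaps fall within the usual scatter of the measurement, so the three compounds cannot be ranked against one another on these data. Among the compounds with values here, no pair among them differs in one place only, so no single-point step is known.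

Compound 4, `CC(=O)Nc1cc(Oc2ccc(NC(=O)Nc3cccc(C(F)(F)F)c3)cc2)ncn1`, is not yet measured. It differs from compound 3 in one place: acetyl in place of propyl on a nitrogen on an aromatic ring.

Within the data shown here, with no measured step of this kind at hand, the expectation rests on compound 3 alone, at 32 nM. A modest rise in the number is expected from the step of a 2.5-fold higher number from compound 3 to compound 4 (0.40 log units; beyond the scatter) in this assay, with wide uncertainty. For compound 4 the estimate in this assay is 80 nM, within a range from 20 nM to 400 nM.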

Compound 4, half-maximal inhibitory concentration: 20 nM
Beside the measured number, compound 4's estimate is 4.0-fold (0.60 log units) above it, and the stated range covers the measured number.
By their numbers in this assay, from the lowest: compounds 1, 4, 3 and 2 (each within the scatter of the next, the first and the last beyond it).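

Within the data shown here, this is the first step that changes one place only, and in this assay it reads a 1.6-fold lower number from compound 3 to compound 4 (0.20 log units; within the scatter) for acetyl in place of propyl on a nitrogen on an aromatic ring. At this position, then, a chain with no hydrogen-bond acceptor and a group with a carbonyl and one hydrogen-bond acceptor give numbers that the measurement cannot tell apart, with the same count of heavy atoms on both sides. Nothing available bears on why the two compounds read alike, so the pair stands as an observation only.

The compounds shown leave open how other groups on this nitrogen would read in this assay, such as methanesulfonyl, cyclopropanecarbonyl or a longer chain such as butyl. They also leave open how the acetamido group would read on the core of compound 1, which carries fluorine, or on the core of compound 2, which carries chlorine, as both of those compounds have methyl on this nitrogen instead.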